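Bromo to methoxy exchange in a three-compound cytotoxicity series

This account rests on a few compounds, and the source may have more. Where it says the series, first, only, none or still open, it means among the compounds named here.

Three compounds have been measured in a functional assay on MCF7 cells (Homo sapiens) for cytotoxicity, read by sulforhodamine B assay, with a stated time of 48 h; on this read-out higher numbers stand for weaker inhibition of growth and lower numbers for stronger inhibition of growth:

Compound 1, `COc1ccc(/C(Cl)=C/C=C(\C#N)C(=O)c2c[nH]c3ccc(Br)cc23)cc1`: 80300 nM
Compound 2, `COc1cc(/C(Cl)=C/C=C(\C#N)C(=O)c2c[nH]c3ccc(Br)cc23)cc(OC)c1OC`: 30800 nM
Compound 3, `COc1ccc(/C(Cl)=C/C=C(\C#N)C(=O)c2c[nH]c3ccc(OC)cc23)cc1`: 87100 nM

Compound 2 gives the lowest number of the three; compound 1 stands nearest and compound 3 furthest, both beyond the usual scatter. The difference between the core of compound 1 and the core of compound 2 is not broken down here.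

For the measured compounds named here, the one change measured twice over is methoxy in place of bromo on an aromatic carbon. Going that way, a 1.1-fold higher number from compound 1 to compound 3 (0.04 log units; within the scatter), so the number hardly moves on the core of compound 1.

Compound 4, `COc1ccc2[nH]cc(C(=O)/C(C#N)=C/C=C(\Cl)c3cc(OC)c(OC)c(OC)c3)c2c1`, is not yet measured. It carries the same change on the core of compound 2: methoxy in place of bromo on an aromatic carbon. The place is worded identically for both pairs, so it is the same change. Because a 1.1-fold higher number from compound 1 to compound 3 (0.04 log units; within the scatter) lies within the scatter, the step for compound 4 is expected to be of the same small size, a 1.1-fold higher number from compound 2 to compound 4 (0.03 log units; within the scatter), in this assay. Compound 4 is estimated at 33000 nM, with a likely span from 15000 nM to 70000 nM.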

Compound 4, concentration for 50% growth inhibition: 39200 nM
Compound 4: the middle estimate sits 1.2-fold (0.07 log units) below what was measured; low and high end bracket the measured number.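

In this assay, methoxy in place of bromo on an aromatic carbon gives a 1.3-fold higher number from compound 2 to compound 4 (0.10 log units; within the scatter), so the exchange is again a small step on the core of compound 2. The step is of similar size on both cores: the same change on two cores in this assay, a 1.1-fold higher number (0.04 log units; within the scatter) from compound 1 to compound 3 and a 1.3-fold higher number (0.10 log units; within the scatter) from compound 2 to compound 4, 1.2-fold (0.07 log units) apart, within the scatter of two such steps. For the compounds shown here, this shows that, on these two cores and in this one assay, the exchange carries over without a step beyond the scatter, but it rests on only two pairs and does not show that bromo and methoxy are interchangeable on other cores, in other cells or at other places on the molecule.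

Only bromo and methoxy occupy this place in the compounds shown, so the outcome with an amine, a carboxylic acid or a longer chain there remains open. Also open, on these data alone, is whether a change at this place that gives a step beyond the scatter on one of these cores would carry over to the other in the same way.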